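The source may hold more compounds than are shown below. What is called first, only, known or untested is meant among the compounds shown, and "the series" means these compounds.

Measured so far in an assay on microsomes from liver for inhibition of 3-hydroxy-3-methylglutaryl-coenzyme A reductase (Rattus norvegicus), read by scintillation counting, with stated times of 0.5 h and 0.75 h; on this read-out higher numbers stand for weaker inhibition and lower numbers for stronger inhibition:
compound 1, `Cc1ccc(CNC(=O)c2nc(-c3ccc(F)cc3)n(CC[C@@H](O)C[C@@H](O)CC(=O)O)c2C2CC2)cc1`; compound 1 gives 1.7 nM
compound 2, `O=C(O)C[C@H](O)C[C@H](O)CCn1c(-c2ccc(F)cc2)nc(C(=O)NCc2ccc(F)cc2)c1C1CC1`; compound 2 gives 3.4 nM

Going by the values given here, compound 2 holds the higher of the two numbers, yet the only step in the set, a 2.0-fold higher number from compound 1 to compound 2 (0.30 log units; within the scatter), stays within the scatter. Compound 3, `COc1ccc(CNC(=O)c2nc(-c3ccc(F)cc3)n(CC[C@@H](O)C[C@@H](O)CC(=O)O)c2C2CC2)cc1`, differs from compound 2 by methoxy in place of fluoro on an aromatic carbon. Among the compounds with values here, the one measured step bears on this change only loosely, and it showed no shift beyond the scatter. Hence no step beyond the scatter is expected in this assay either: a 1.2-fold lower number from compound 2 to compound 3 (0.08 log units; within the scatter) is the estimated move. Compound 3 is expected at 2.8 nM, with a range from 1 nM to 8 nM.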

Compound 3, half-maximal inhibitory concentration: 1.2 nM
Beside the measured number, compound 3's estimate is 2.3-fold (0.37 log units) above it, and the stated range covers the measured number.
By their numbers in this assay, from the lowest: compounds 3, 1 and 2 (each within the scatter of the next, the first and the last beyond it).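

In this assay, going by these compounds alone, 4-methoxybenzyl in place of 4-fluorobenzyl gives a 2.8-fold lower number from compound 2 to compound 3 (0.45 log units; beyond the scatter) as the first step in the set beyond the scatter, so this position does respond to the group it carries, if modestly. Methyl and methoxy are not separated here, as a 1.4-fold lower number from compound 1 to compound 3 (0.15 log units; within the scatter) stays within the scatter. No measurement at hand offers an explanation for the step.

Open, as far as these compounds go, is how an amine, a hydroxy group or a longer ether such as ethoxy would read at this position. Also open, from the compounds shown here alone, is whether methoxy in place of fluoro gives a similar step on the other 4-fluorophenyl group, the one on the shared core.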